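A few compounds are considered here, and "the series" means these few. Any claim that something is new, unique, unknown or untested is made for them only; others in the source may bear on it.

Measured so far in a functional assay on HeLa cells (Homo sapiens) for antiproliferative activity, read by MTT assay, with a stated time of 48 h; on this read-out lower numbers stand for stronger inhibition and higher numbers for weaker inhibition
- compound 1 `COc1ccc(-c2cc3c(cn2)[nH]c(=O)n3-c2cc(OC)c(OC)c(OC)c2)cc1` gives 1210 nM
- compound 2 `CCOc1ccc(-c2cc3c(cn2)[nH]c(=O)n3-c2cc(OC)c(OC)c(OC)c2)cc1` gives 3730 nM

Compound 2 stands at 3730 nM as the higher of the two numbers and so is the weaker of the pair. Among the measured compounds shown here, the one measured step is a 3.1-fold higher number from compound 1 to compound 2 (0.49 log units; beyond the scatter) and goes with methyl in place of hydrogen on a saturated chain carbon bound to an oxygen on an aromatic ring.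

Compound 3 `CCOc1ccc(-c2cc3c(cn2)[nH]c(=O)n3-c2cc(OC)c(OC)c(OC)c2)cc1F` keeps the ethoxy group and differs by fluoro in place of hydrogen on an aromatic carbon with fluoro in place of hydrogen on an aromatic carbon, so that 4-ethoxyphenyl becomes 4-ethoxy-3-fluorophenyl. For the measured compounds named here, no measured step touches that aromatic carbon, and direct evidence is lacking. Going by the values given here, the step of a 3.1-fold higher number from compound 1 to compound 2 (0.49 log units; beyond the scatter) is the only guide, and it gives a rough scale but no direction for this change. In this assay a step no larger than that one is expected, most likely within the scatter. The estimate is a 1.2-fold lower number from compound 2 to compound 3 (0.07 log units; within the scatter) as an expected step without a firm direction. Compound 3 is estimated at 3200 nM with an expected range of 1100 nM to 9000 nM in this read-out.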

Compound 3, half-maximal inhibitory concentration: 2870 nM
Compound 3: middle estimate off by 1.1-fold (0.05 log units), on the high side; the range from low to high includes it.
By their numbers in this assay, from the lowest: compound 1; then compounds 3 and 2 (each within the scatter of the next).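

In this assay fluoro in place of hydrogen on an aromatic carbon, ortho to an ethoxy group, gives a 1.3-fold lower number from compound 2 to compound 3 (0.11 log units; within the scatter) and leaves compound 2 and compound 3 indistinguishable in this read-out, so this position accepts a fluoro with no step beyond the scatter. Set against the 4-methoxyphenyl group, the 4-ethoxy-3-fluorophenyl group gives a 2.4-fold higher number from compound 1 to compound 3 (0.38 log units; beyond the scatter) and sits alongside a 3.1-fold higher number from compound 1 to compound 2 (0.49 log units; beyond the scatter) in the same modest range, so the fluoro does not close the gap to compound 1, which keeps the lowest number of the three. No independent measurement bears on the reason for this result.

Still open, on these data alone, is whether fluoro at this place on the 4-methoxyphenyl group of compound 1 would also give a step within the scatter, or whether the outcome holds only alongside ethoxy. Also open, as far as these compounds go, is how larger or different groups would read at this aromatic carbon, such as chloro, a hydroxyl or an amine, and how a longer chain such as propoxy would read in place of ethoxy.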